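Swapping One Halogen on the Shared Core

A few compounds are considered here, and "the series" means these few. Any claim that something is new, unique, unknown or untested is made for them only; others in the source may bear on it.

Of the compounds shown here, three with a shared sulfur-bearing acid side chain have been measured in an assay on isolated protein for inhibition of Calpain-1 catalytic subunit (Sus scrofa); a lower number here means a stronger inhibitor, a higher number a weaker inhibitor. Compound 1 `O=C(O)/C(S)=C/c1c[nH]c2ccc(F)cc12` gives 930 nM in this assay. Compound 2 `O=C(O)/C(S)=C/c1c[nH]c2c(I)cccc12` gives 220 nM, the lowest of the three numbers and so the strongest inhibitor shown; compound 1 stands beyond the scatter above it. Compound 3 `O=C(O)/C(S)=C/c1cccc(I)c1`, which lacks the shared fused core and carries its iodo group on a lone six-membered ring, gives 23900 nM, far weaker than either fused compound.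

Compound 4 `O=C(O)/C(S)=C/c1c[nH]c2c(Cl)cccc12` keeps everything of compound 2 except a single atom: chloro in place of iodo on an aromatic carbon. Going by the values given here, no pair of measured compounds differs by exactly this exchange, so the size of the step has to be estimated. Compound 1 and compound 2 show that a halogen on the fused core is compatible with strong inhibition, but they differ in both the halogen and where it sits, so they do not isolate the halogen itself. The expectation is a modest loss of potency, a step of a 1.8-fold higher number from compound 2 to compound 4 (0.26 log units; within the scatter) that may stay within the scatter. Compound 4 is therefore expected to give about 400 nM, with a likely range from 150 nM to 1100 nM.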

Compound 4, half-maximal inhibitory concentration: 90 nM
Beside the measured number, compound 4's estimate is 4.4-fold (0.65 log units) above it; measured number outside the range, below it.
By their numbers in this assay, from the lowest: compound 4; then compound 2; then compound 1; then compound 3.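

In this assay, the step of a 2.4-fold lower number from compound 2 to compound 4 (0.39 log units; beyond the scatter) comes from chloro in place of iodo on the same aromatic carbon of the shared core, with nothing else changed. Going by these compounds alone, this is the first pair that isolates the halogen, and it shows that the choice of halogen at this position affects the measured potency, since the change is beyond the usual scatter of repeated measurements. It also shows that iodo is not needed here for strong inhibition. The number falls rather than rises when the iodine atom leaves and a chlorine atom takes its place. No measurement is available that explains why this exchange lowers the number, so the step stands as an observation only.

The compounds shown leave open whether the trend continues with other groups on this aromatic carbon, such as bromo, methyl or methoxy, or with no group there at all. They also leave open whether chloro would give a similar step at another position on the shared core, since this exchange is seen at only one place.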